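Chalcone-linked lactone series: halogen swap on the aryl ring

The compounds below may be only part of what the source reports. "The series", "measured", "known", "first", "only" and "open" are said of these compounds alone.

Measured so far in a functional assay on DU-145 cells (Homo sapiens) for antiproliferative activity, read by MTT assay, with a stated time of 72 h; on this read-out lower numbers stand for stronger inhibition and higher numbers for weaker inhibition:
compound 1 `O=C(COc1ccc(C(=O)/C=C/c2ccc(Cl)cc2Cl)cc1)N[C@H]1CCOC1=O`, 8610 nM
compound 2 `O=C1OCC[C@@H]1NC(=S)SCCOc1ccccc1`, 63800 nM
compound 3 `O=C1OCC[C@@H]1NC(=S)SCCOc1ccccc1Cc1ccccc1`; its result is a limit of the assay, > 64000 nM

Compound 1 gives the lowest of the two numbers shown in this assay; compound 2 sits well beyond the scatter from it. Among the compounds with values here, the only measured step, a number no lower from compound 2 to compound 3 (the limit leaves the size open), runs into the limit of > 64000 nM in this assay, at which 1 of the 3 values shown sits, and is of unreadable size.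

Compound 4 `O=C(COc1ccc(C(=O)/C=C/c2ccc(F)cc2)cc1)N[C@H]1CCOC1=O` differs from compound 1 by 4-fluorophenyl in place of 2,4-dichlorophenyl on a double-bonded chain carbon bound to a double-bonded chain carbon. Within the data shown here, no measured step touches that change, so no size can be carried over. Compound 4 is expected to land close to compound 1, with the shift a 1.4-fold higher number from compound 1 to compound 4 (0.14 log units; within the scatter) kept within or near the scatter. The estimate for compound 4 is 12000 nM, between 4000 nM and 40000 nM.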

Compound 4, half-maximal inhibitory concentration: 18800 nM
Compound 4: middle estimate off by 1.6-fold (0.19 log units), on the low side, within the range that was stated.
By their numbers in this assay, from the lowest: compound 1; then compound 4; then compound 2. At a limit, above all of these: compound 3.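

Swapping the aryl group on a double-bonded chain carbon bound to a double-bonded chain carbon gives a readable step in this assay: a 2.2-fold higher number from compound 1 to compound 4 (0.34 log units; beyond the scatter). This aryl group therefore affects the read-out, but the step is modest, and 4-fluorophenyl in place of 2,4-dichlorophenyl changes both the halogen and the number of halogens at once. Nothing measured here bears on why the number moves.

Whether the halogen or the substitution pattern accounts for the step remains open. A 4-chlorophenyl or an unsubstituted phenyl group would help to separate the two.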